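This account rests on a few compounds, and the source may have more. Where it says the series, first, only, none or still open, it means among the compounds named here.

For the measured compounds named here, in an ADME assay on the whole organism (blood) for pharmacokinetics, with Canis familiaris (Canis lupus familiaris) as the target (a lower number here means that the compound disappears faster, a higher number that the compound lasts longer), compound 1 `COCC1(COC)Oc2ccc(C#N)cc2[C@@H](Nc2ccc(O)nn2)[C@@H]1O` gives 0.0433 h, and compound 2 `COCC1(COC)Oc2ccc(C#N)cc2[C@@H](Nc2ccc(=O)n(C(C)C)n2)[C@@H]1O` gives 0.0917 h, the higher of the two numbers; the one measured step, a 2.1-fold higher number from compound 1 to compound 2 (0.33 log units; beyond the scatter), put a group onto the same aromatic nitrogen that is now changed. Compound 3 `COCCn1nc(N[C@@H]2c3cc(C#N)ccc3OC(COC)(COC)[C@H]2O)ccc1=O` differs from compound 2 by 2-methoxyethyl in place of isopropyl on an aromatic nitrogen. Going by the values given here, no measured step swaps one such group for another, so the earlier step offers only loose guidance. Compound 3 is therefore expected to stay close to compound 2, with a step of a 1.1-fold lower number from compound 2 to compound 3 (0.06 log units; within the scatter) in this assay. The estimate for compound 3 is 0.08 h, within a range from 0.04 h to 0.16 h.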

Compound 3, half-life: 0.0267 h
Estimate against measurement, compound 3: 3.0-fold (0.48 log units) above; measured number below the stated range.
By their numbers in this assay, from the lowest: compounds 3 and 1 (each within the scatter of the next); then compound 2.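

In this assay, the choice of chain on this aromatic nitrogen matters even between two small, ringless groups: 2-methoxyethyl in place of isopropyl gives a 3.4-fold lower number from compound 2 to compound 3 (0.54 log units; beyond the scatter). The position therefore responds to the kind of group it carries, and the entering chain differs by holding a hydrogen-bond acceptor, which isopropyl lacks. Nothing available explains the drop. On these data alone, it remains open whether the chain's oxygen is what matters, and how a plain butyl chain or a chain ending in an amine would behave at this nitrogen.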